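This account rests on a few compounds, and the source may have more. Where it says the series, first, only, none or still open, it means among the compounds named here.

Measured so far:
compound 1 `COc1cc(NC(=O)Nc2cc(Nc3cc(C)cc(F)c3)ncn2)cc(OC)c1`: 64.5%
compound 2 `COc1cc(Nc2cc(NC(=O)Nc3c(Cl)cccc3Cl)ncn2)cc(C(F)(F)F)c1`: 88.5%
compound 3 `Cc1cc(F)cc(Nc2cc(NC(=O)Nc3c(Cl)cccc3Cl)ncn2)c1`: 80%

All three numbers come from a functional assay on PC-9 cells (Homo sapiens) for inhibition, read by MTT assay, with a stated time of 48 h, tested at 10 uM; on this read-out higher numbers stand for more inhibition at the one concentration tested (going by the name of the read-out) and lower numbers for less inhibition. Compound 1 gives the lowest of the three in this assay; compound 3 sits higher by an amount beyond the scatter, and compound 2 higher still, also beyond the scatter. No two of these compounds differ in a single place, so no measured step is available to guide the next compound.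

Compound 4 `COc1cc(NC(=O)Nc2cc(Nc3ccc(C)c(C)c3)ncn2)cc(OC)c1` differs from compound 1 in one place: 3,4-dimethylphenyl in place of 3-fluoro-5-methylphenyl on a nitrogen on an aromatic ring. With nothing comparable on record, the step from compound 1 to compound 4 in this assay is expected to stay within the scatter, in either direction. Compound 4 is therefore estimated at 62%, with a range from 45% to 78%, which amounts to an expected step of a number 2.5 percentage points lower from compound 1 to compound 4 (within the scatter).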

Compound 4, a percentage reported as inhibition, at one concentration (the size of the read-out at that concentration, not a potency): 66%
Compound 4: the middle estimate sits 4 percentage points below what was measured, and the stated range covers the measured number.
By their numbers in this assay, from the lowest: compounds 1 and 4 (each within the scatter of the next); then compounds 3 and 2 (each within the scatter of the next).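

In this assay, going by these compounds alone, 3,4-dimethylphenyl in place of 3-fluoro-5-methylphenyl on a nitrogen on an aromatic ring amounts to a number 1.5 percentage points higher from compound 1 to compound 4 (within the scatter) and gives the first measured step at this position. On this single pair, the fluorine can go and the methyl pattern can change without a shift beyond the scatter. Nothing on hand explains this outcome. Still open, going by these compounds, is whether a group carrying an amine or a carboxylic acid on this ring would hold the number. Also open, on these data alone, is whether the same change would behave alike in compound 3, which carries the same 3-fluoro-5-methylphenyl group.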